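A few compounds are considered here, and "the series" means these few. Any claim that something is new, unique, unknown or untested is made for them only; others in the source may bear on it.

Measured in an assay on HEK293 cells for inhibition of N-acylethanolamine-hydrolyzing acid amidase (Rattus norvegicus), with a stated time of 30 min; on this read-out higher numbers stand for weaker inhibition and lower numbers for stronger inhibition:
- compound 1 `O=C(CCCCCCc1ccccc1)N[C@H]1COC1=O`: 1500 nM
- compound 2 `O=C(CCc1ccccc1)N[C@H]1CCOC1=O`: > 100000 nM
- compound 3 `O=C(CCc1ccccc1)NC1CCC1`: > 100000 nM

Compound 3 stands at the limit of this assay: its reading > 100000 nM is a limit, not a number. Compound 2 likewise returns only a limit. Among the compounds with values here, the single numerical value in the set belongs to compound 1, so two of the three readings sit at the limit of > 100000 nM in this assay, at which 2 of the 3 values shown sit.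

Compound 4 `O=C(CCc1ccccc1)NC1CCC1=O` is not yet measured. It differs from compound 3 by 2-oxocyclobutyl in place of cyclobutyl on an amide-type nitrogen. Within the data shown here, no step between two measured compounds that differ in one place is available, so the expectation rests on this change alone. A step beyond the usual scatter toward stronger inhibition from compound 3 to compound 4 is expected an at least 2.5-fold lower number from compound 3 to compound 4 (0.39 log units; beyond the scatter). For compound 4 the estimate is 40000 nM, ranging from 4000 nM to 100000 nM, with a real chance that only a limit is reported.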

Compound 4, half-maximal inhibitory concentration: > 10000000 nM
Compound 4: a limit, no number; the forecaster's own chance of this, stated with the estimate: 45%; middle value at least 250-fold (2.39 log units) away from the limit.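

Within the data shown here, compound 3 and compound 4 each return only a limit, not a number, so no step between them can be read. The compounds shown leave open whether 2-oxocyclobutyl in place of cyclobutyl on an amide-type nitrogen changes inhibition at all.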